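Chlorination on the sulfonyl phenyl of a weak cytotoxic hydantoin

The source may hold more compounds than are shown below. What is called first, only, known or untested is meant among the compounds shown, and "the series" means these compounds.

Compound 2 `Cc1ccc(C2CNC(=O)N2S(=O)(=O)c2ccccc2)cc1` gives the highest number of the two measured in a functional assay on SK-MEL-2 cells (Homo sapiens) for cytotoxicity (on this read-out higher numbers stand for weaker inhibition and lower numbers for stronger inhibition), at 144000 nM. Its nearest neighbour, compound 1 `O=C1NC(c2ccc(Br)cc2)CN1S(=O)(=O)c1ccc2c(c1)CCC2`, gives 32600 nM in this assay, a gap beyond the scatter. Compound 3 `Cc1ccc(C2CNC(=O)N2S(=O)(=O)c2ccc(Cl)cc2)cc1` differs from compound 2 by chloro in place of hydrogen on an aromatic carbon, on an aromatic carbon of a six-membered aromatic ring of carbon only, para to a large group. For the measured compounds named here, no step between measured compounds covers this change, so the size of its effect is open. A modest shift to a lower number is expected, with a 1.8-fold lower number from compound 2 to compound 3 (0.26 log units; within the scatter), and compound 3 is estimated at 80000 nM, between 30000 nM and 250000 nM.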

Compound 3, half-maximal inhibitory concentration: 255000 nM
Compound 3: middle estimate off by 3.2-fold (0.50 log units), on the low side, and the stated range ends below it.
By their numbers in this assay, from the lowest: compound 1; then compounds 2 and 3 (each within the scatter of the next).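

In this assay, the change from phenyl to 4-chlorophenyl, on an aromatic carbon para to a large group, gives a step that cannot be told from repeat measurements (a 1.8-fold higher number from compound 2 to compound 3 (0.25 log units; within the scatter)). At this position, then, a single chlorine in place of hydrogen leaves the read-out within the scatter. Nothing available accounts for this result. On these data alone, whether an amine, a methoxy group or a carboxylic acid at the same place would move the number beyond the scatter remains open.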